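Shortening the Aryl Chain: Compound 2 to Compound 3

A few compounds are considered here, and "the series" means these few. Any claim that something is new, unique, unknown or untested is made for them only; others in the source may bear on it.

Of the compounds shown here, two that share one core have been measured in a functional assay on CCRF-CEM cells (Homo sapiens) for antiproliferative activity, read by MTT assay, with a stated time of 96 h; on this read-out higher numbers stand for weaker inhibition and lower numbers for stronger inhibition. Compound 1 `O=C1NC(=O)C2(CSC3=C2C(=O)c2ncccc2C3=O)N1` carries only hydrogen on the amide-type nitrogen in its ring, and in this assay compound 1 gives 120 nM. Going by the values given here, compound 2 `CCc1ccc(N2C(=O)NC3(CSC4=C3C(=O)c3ncccc3C4=O)C2=O)cc1` has a 4-ethylphenyl group in that place, and in this assay compound 2 gives 10 nM, the lowest of the two numbers; the only other value is that of compound 1, and the step of a 12-fold lower number from compound 1 to compound 2 (1.08 log units; beyond the scatter) shows how much the aryl group changed the read-out.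

Compound 3 `Cc1ccc(N2C(=O)NC3(CSC4=C3C(=O)c3ncccc3C4=O)C2=O)cc1` keeps the aryl group but is changed in its chain: hydrogen in place of methyl on a saturated chain carbon bound to an aromatic carbon. Among the compounds with values here, no measured step tests what the length of that chain does; the one step available concerns the whole aryl group. A change of a single carbon at the end of a chain is expected to shift the number only modestly, so in this assay the step of a 1.5-fold higher number from compound 2 to compound 3 (0.18 log units; within the scatter) is estimated to stay within the scatter, perhaps slightly toward a higher number. Compound 3 is therefore estimated at 15 nM, within a range from 5 nM to 45 nM.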

Compound 3, half-maximal inhibitory concentration: 20 nM
Estimate against measurement, compound 3: 1.3-fold (0.12 log units) below, and the stated range covers the measured number.
By their numbers in this assay, from the lowest: compounds 2 and 3 (each within the scatter of the next); then compound 1.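

Replacing 4-ethylphenyl with 4-methylphenyl gives a 2.0-fold higher number from compound 2 to compound 3 (0.30 log units; within the scatter) in this assay, so this read-out cannot separate the two groups, and the low number of compound 2 does not depend on the chain being ethyl rather than methyl. The effect of placing an aryl group on the amide-type nitrogen also holds with the shorter chain: 4-methylphenyl in place of hydrogen gives a 6.0-fold lower number from compound 1 to compound 3 (0.78 log units; beyond the scatter), so two different aryl groups now stand beyond the scatter from the unsubstituted compound, where only one could be judged before. No independent evidence is available to explain either step.

These compounds leave open how far the chain can be changed, since neither a plain phenyl group with hydrogen in place of the chain nor a longer chain such as propyl or butyl appears among them. They also do not show whether a group of a different kind in place of the ethyl or methyl group, such as an amine or a carboxylic acid, would keep the number close to those of compound 2 and compound 3.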